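Enantiomer of compound 1 in clearance

The source may hold more compounds than are shown below. What is called first, only, known or untested is meant among the compounds shown, and "the series" means these compounds.

Compound 1 `CN(C)Cc1ccccc1-c1ccc(C(=O)N[C@H](CC(=O)Nc2ccc(Cl)cn2)C(=O)N2CCCCC2)cc1` gives the highest of the two numbers in an in vivo ADME assay on the whole organism (plasma, Rattus norvegicus) for pharmacokinetics (a lower number here means slower removal, a higher number faster removal of the compound), at 178 mL/min/kg. Within the data shown here, compound 2 `NS(=O)(=O)c1ccccc1-c1ccc(C(=O)NC(CC(=O)Nc2ccc(Br)cn2)C(=O)O)cc1` in this assay gives 6.7 mL/min/kg, a far lower number, and no single-change step connects it to compound 1. Compound 3 `CN(C)Cc1ccccc1-c1ccc(C(=O)N[C@@H](CC(=O)Nc2ccc(Cl)cn2)C(=O)N2CCCCC2)cc1` is not yet measured; relative to compound 1 (the two compounds have the same atoms and bonds and differ only in configuration as drawn: 1 of 1 stereo elements differ; a stereocentre at a saturated chain carbon is drawn R in compound 1 and S in compound 3). Among the measured compounds shown here, no measured step tells how such a change in configuration alone shifts this assay. The step from compound 1 to compound 3 is expected to stay within the scatter, in either direction, a 1.2-fold lower number from compound 1 to compound 3 (0.07 log units; within the scatter). Compound 3 is expected to give about 150 mL/min/kg in this assay, between 60 mL/min/kg and 400 mL/min/kg.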

Compound 3, clearance: 124 mL/min/kg
Beside the measured number, compound 3's estimate is 1.2-fold (0.08 log units) above it; the measured number falls inside the stated range.
By their numbers in this assay, from the lowest: compound 2; then compounds 3 and 1 (each within the scatter of the next).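

In this assay the series now has its first single-change step, and it lies within the scatter: a 1.4-fold lower number from compound 1 to compound 3 (0.16 log units; within the scatter). At this saturated chain carbon, drawn R or S, configuration alone therefore gives no readable separation in this pair. No other structural change enters this comparison: the fact that compounds 1 and 3 differ only in the configuration as drawn. On these data alone, whether this holds once another group is present, such as a methyl ester or a primary amine on the core of compound 1, remains open. One enantiomer pair also sets no pattern for the wider series.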